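The source may hold more compounds than are shown below. What is called first, only, known or untested is meant among the compounds shown, and "the series" means these compounds.

Measured compounds:
Compound 1, `Cc1cc(=O)cc2c3c1[C@@H](O)[C@H]1[C@@H]3[C@]3(CC2)C(=O)O[C@@H]1CC3C`, gives 10300 nM in a functional assay on A549 cells (Homo sapiens) for inhibition, read by CCK-8 assay, with a stated time of 72 h; on this read-out higher numbers stand for weaker inhibition and lower numbers for stronger inhibition.
Compound 2, `Cc1cc(=O)cc2c3c1C[C@@H]1[C@@H]4OC(=O)[C@](C[C@H]2O)(C(C)C4O)[C@H]31`, gives 25400 nM in this assay.

Compound 2 has the higher of these two numbers, and its gap to compound 1 lies beyond the usual scatter of repeated measurements, so compound 2 is the weaker inhibitor of the two. Compound 3, `Cc1cc(=O)cc2c3c1C[C@H]1[C@@H]3[C@]3(C[C@H]2O)C(=O)O[C@@H]1CC3C`, is compound 2 with one change: hydrogen in place of hydroxy on a saturated ring carbon. Among the measured compounds shown here, only two compounds have been measured, and no pair among them differs in a single place, so there is no directly comparable step to lean on. The expectation is a small shift toward a lower number, which would mean somewhat stronger inhibition, or none beyond the scatter. On that basis compound 3 is estimated at 15000 nM, with a likely range from 5000 nM to 45000 nM, an expected step of a 1.7-fold lower number from compound 2 to compound 3 (0.23 log units; within the scatter).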

Compound 3, half-maximal inhibitory concentration: 22000 nM
Beside the measured number, compound 3's estimate is 1.5-fold (0.17 log units) below it; low and high end bracket the measured number.
By their numbers in this assay, from the lowest: compound 1; then compounds 3 and 2 (each within the scatter of the next).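

In this assay, putting hydrogen in place of hydroxy on this saturated ring carbon gives a 1.2-fold lower number from compound 2 to compound 3 (0.06 log units; within the scatter). Among the compounds shown here, this is the first comparison here between compounds that differ in only one place, and it shows that the hydroxy on this carbon is not needed to keep the level of inhibition seen with compound 2. No measurement shown here accounts for this result.

Only hydroxy and hydrogen are shown on this carbon, so it remains open whether an amine, a carboxylic acid or a longer carbon chain there would shift the number beyond the usual scatter. On these data alone, it also remains open whether a methoxy group or a fluorine atom, which stay closer in size to the hydroxy, would read the same way.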